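Benzofuran in place of thiophene: notes on compound 4

The compounds below may be only part of what the source reports. "The series", "measured", "known", "first", "only" and "open" are said of these compounds alone.

Measured so far in a functional assay on K562 cells (Homo sapiens), read by MTT assay, with a stated time of 72 h; a higher number here means a weaker inhibitor, a lower number a stronger inhibitor

- compound 1 `COc1ncnc2c1c(-c1cc3ccccc3o1)cn2[C@@H]1O[C@H](CO)[C@@H](O)[C@H]1O` gives 13100 nM
- compound 2 `CNc1ncnc2c1c(-c1cc3ccccc3o1)cn2[C@@H]1O[C@H](CO)[C@@H](O)[C@H]1O` gives > 20000 nM (a limit)
- compound 3 `Cc1ncnc2c1c(-c1cccs1)cn2[C@@H]1O[C@H](CO)[C@@H](O)[C@H]1O` gives > 20000 nM (a limit)

Compound 3 stands at the limit of > 20000 nM in this assay, at which 2 of the 3 values shown sit, and so has a limit and no number. The next step leads to compound 4 `Cc1ncnc2c1c(-c1cc3ccccc3o1)cn2[C@@H]1O[C@H](CO)[C@@H](O)[C@H]1O`, which carries 1-benzofuran-2-yl in place of thiophen-2-yl on an aromatic carbon.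

Among the measured compounds shown here, no measured step makes this exchange. For the measured compounds named here, the one measured step, an at least 1.5-fold higher number from compound 1 to compound 2 (0.18 log units; that floor lies within the scatter), lies at another place on the shared core, and its floor is within the scatter, so it offers no size to carry over. Only indirect support remains. Compound 1 also carries 1-benzofuran-2-yl and reads as a true number (13100 nM). Compound 2 carries the same group and gives only a limit (> 20000 nM). The group therefore does not guarantee a number.

Going by the values given here, with compound 1 at 13100 nM as the sole guide, a modest lowering in this assay is expected, and possibly none beyond the scatter. The expected size is an at least 1.4-fold lower number from compound 3 to compound 4 (0.15 log units; that floor lies within the scatter) and a second reading at the limit remains quite possible. For compound 4 the estimated value is 14000 nM within a wide range (5000 nM to 20000 nM).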

Compound 4, half-maximal inhibitory concentration: > 20000 nM
Compound 4 gave a limit, no number (the forecaster's own chance of this, stated with the estimate: 45%); at least 1.4-fold (0.15 log units) between middle value and limit.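

Compound 4, which carries 1-benzofuran-2-yl in place of thiophen-2-yl, gives > 20000 nM in this assay, a limit and not a number, so this exchange on an aromatic carbon yields no number with methyl on the shared core. The steps to compound 4 from compound 3 and from compound 2 cannot be read, as both ends of each are limits. The one readable step, methyl in place of methoxy on an aromatic carbon, is an at least 1.5-fold higher number from compound 1 to compound 4 (0.18 log units; that floor lies within the scatter), so it gives no size beyond the scatter, and compound 1 is now the only compound shown with a number, the other three sharing one value: the limit of > 20000 nM in this assay, at which 3 of the 4 values shown sit.

Still open is whether the exchange of thiophen-2-yl for 1-benzofuran-2-yl has any size at all, as no pair shown has a number at both ends. Also open, from the compounds shown here alone, is whether a dimethylamino group or a longer alkoxy chain in place of methoxy, with 1-benzofuran-2-yl kept, would give a number in this assay.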